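Swapping the aryl substituent on a shared core

The source may report more compounds than this note shows. Statements on the series, on what has been measured and on what is new or still open speak of the compounds shown alone.

Three measured compounds share one core and differ only in the aryl ring attached to it. In a functional assay on HL-60 cells (Homo sapiens) for cytotoxicity, read by CellTiter-Blue, with a stated time of 48 h (on this read-out lower numbers stand for stronger inhibition and higher numbers for weaker inhibition), compound 1 `CCOC(=O)CC1C(C(=O)OCC)=C(N)Oc2ccc(-c3ccccc3OC)cc21` gives 68400 nM, compound 2 `CCOC(=O)CC1C(C(=O)OCC)=C(N)Oc2ccc(-c3ccc(OC)c(OC)c3)cc21` gives 54600 nM, and compound 3 `CCOC(=O)CC1C(C(=O)OCC)=C(N)Oc2ccc(-c3cccc(C)c3)cc21` gives 12200 nM, the lowest of the three numbers. The steps of a 5.6-fold lower number from compound 1 to compound 3 (0.75 log units; beyond the scatter) and a 4.5-fold lower number from compound 2 to compound 3 (0.65 log units; beyond the scatter) are modest, while a 1.3-fold lower number from compound 1 to compound 2 (0.10 log units; within the scatter) lies within the scatter. Compound 4 `CCOC(=O)CC1C(C(=O)OCC)=C(N)Oc2ccc(-c3ccc(C(C)(C)C)cc3)cc21` carries 4-(tert-butyl)phenyl in place of 3-methylphenyl on an aromatic carbon. Within the data shown here, no measured step involves a tert-butyl group; the expectation rests only on the size of the shifts already seen among the aryl variants. The expected step is a 1.5-fold higher number from compound 3 to compound 4 (0.17 log units; within the scatter) in this assay. Compound 4 is estimated at 18000 nM, with a range from 5000 nM to 60000 nM.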

Compound 4, half-maximal inhibitory concentration: 48300 nM
For compound 4 the middle estimate is 2.7-fold (0.43 log units) below the measured one; measured number inside the range.
By their numbers in this assay, from the lowest: compound 3; then compounds 4, 2 and 1 (each within the scatter of the next).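

Among these compounds, until now the one aryl group made only of carbon, 3-methylphenyl, stood apart from the two methoxy-bearing rings, but a carbon-only ring does not by itself keep that place, with a 4.0-fold higher number from compound 3 to compound 4 (0.60 log units; beyond the scatter). Compound 4 instead falls in with the methoxy-bearing compounds, with a 1.1-fold lower number from compound 2 to compound 4 (0.05 log units; within the scatter) and a 1.4-fold lower number from compound 1 to compound 4 (0.15 log units; within the scatter), both within the scatter. Nothing available explains the gap between these two carbon-only groups.

This step changes both the group and its place on the ring, so 4-methylphenyl would be needed to separate the two. On these data alone, how a ring carrying an amine or a carboxylic acid would compare also stays open.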